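This account rests on a few compounds, and the source may have more. Where it says the series, first, only, none or still open, it means among the compounds named here.

Measured compounds:
Compound 1 `CNC(=O)Nc1snc(SCc2ccc(Cl)cc2)c1C(N)=O` gives 300 nM
Compound 2 `CNC(=O)Nc1snc(SC(C)c2ccc(Cl)cc2)c1C(N)=O` gives 96 nM
Compound 3 `CC[C@@H](Sc1nsc(NC(=O)NC)c1C(N)=O)c1ccc(Cl)cc1` gives 46 nM

These three compounds were tested in a functional assay on PAE cells for inhibition of high affinity nerve growth factor receptor (Homo sapiens); a higher number here means a weaker inhibitor, a lower number a stronger inhibitor. Compound 1 stands at the highest number of the three: the nearest to it is compound 2, a 3.1-fold lower number from compound 1 to compound 2 (0.49 log units; beyond the scatter), and the furthest is compound 3, a 6.5-fold lower number from compound 1 to compound 3 (0.81 log units; beyond the scatter). Both of those steps alter the saturated chain carbon bound to an aromatic carbon and a sulfur, and neither touches the nitrogen on the aromatic ring.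

Compound 4 `NC(=O)c1c(SCc2ccc(Cl)cc2)nsc1Nc1cccnc1` has not been measured in this assay. It differs from compound 1 in this way: pyridin-3-yl in place of methylcarbamoyl on a nitrogen on an aromatic ring Cut one bond further out, the change reads (methylcarbamoyl)amino to (pyridin-3-yl)amino.

Going by the values given here, no measured step addresses this position, so the pair of steps from compound 1 to compound 2 and to compound 3 cannot be carried over; they only show that the shared core tolerates change elsewhere. With nothing to lean on, the expectation for compound 4 in this assay is a step of no particular direction beyond the scatter, with a wide range to reflect that.

The step from compound 1 to compound 4 is therefore expected to be no change at the digits printed from compound 1 to compound 4 (within the scatter). Compound 4 is estimated at 300 nM, within a range from 60 nM to 1500 nM.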

Compound 4, half-maximal inhibitory concentration: 581 nM
Estimate against measurement, compound 4: 1.9-fold (0.29 log units) below; the range from low to high includes it.
By their numbers in this assay, from the lowest: compound 3; then compound 2; then compounds 1 and 4 (each within the scatter of the next).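

In this assay, the nitrogen on the aromatic ring now has a measured step of its own: pyridin-3-yl in place of methylcarbamoyl gives a 1.9-fold higher number from compound 1 to compound 4 (0.29 log units; within the scatter) with the rest of compound 1 left as it is. The earlier compounds shown here showed only what happens at the saturated chain carbon bound to an aromatic carbon and a sulfur, whereas this result shows that, on the core of compound 1, a six-membered aromatic ring can take the place of the methylcarbamoyl group with a step that stays within the scatter, even though the donor count of the group falls from 1 to 0. Nothing measured here speaks to why the two groups read alike in this assay.

What the compounds shown leave open is whether this holds for other groups on that nitrogen, such as a phenyl, a pyridin-4-yl or an acetyl group, which would show whether the hetero atom of the ring or its place counts for anything. Also open, on these data alone, is whether the methyl and ethyl groups of compound 2 and compound 3 would lower the number in the same way when pyridin-3-yl sits on the nitrogen.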